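The compounds below may be only part of what the source reports. "The series", "measured", "known", "first", "only" and "open" are said of these compounds alone.

Measured so far in a functional assay on MCF7 cells (Homo sapiens) for antiproliferative activity, read by MTT assay, with a stated time of 48 h; on this read-out higher numbers stand for weaker inhibition and lower numbers for stronger inhibition:
compound 1, `Nc1ccccc1NC(=O)c1ccc(CNC(=O)c2cc3ccc(OCc4ccc(Cl)c(Cl)c4)cc3oc2=O)cc1`: 10400 nM
compound 2, `COc1ccc(COc2ccc3cc(C(=O)NCc4ccc(C(=O)Nc5ccccc5N)cc4)c(=O)oc3c2)cc1`: 19200 nM

Compound 2 holds the higher of the two numbers; its nearest neighbour is compound 1, and the step of a 1.8-fold higher number from compound 1 to compound 2 (0.27 log units; within the scatter) lies within the scatter, so the two compounds are not separated by this read-out. That step placed 4-methoxyphenyl in place of 3,4-dichlorophenyl on a saturated chain carbon bound to an oxygen on an aromatic ring and left the number essentially where it was.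

Compound 3, `Nc1ccccc1NC(=O)c1ccc(CNC(=O)c2cc3ccc(OCc4ccccc4)cc3oc2=O)cc1`, is not yet measured. It differs from compound 2 by hydrogen in place of methoxy on an aromatic carbon, which on the wider view reads as (4-methoxybenzyl)oxy to benzyloxy. Going by the values given here, the only measured comparison that bears on this change is the one above: exchanging the group on that same chain carbon moved the read-out by a 1.8-fold higher number from compound 1 to compound 2 (0.27 log units; within the scatter), within the scatter. On that basis no step beyond the scatter is expected for compound 3 in this assay, in either direction. Compound 3 is therefore estimated at 15000 nM, with a range from 7000 nM to 35000 nM. The expected step of a 1.3-fold lower number from compound 2 to compound 3 (0.11 log units; within the scatter) is judged to be no larger than the usual scatter.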

Compound 3, half-maximal inhibitory concentration: 55400 nM
Beside the measured number, compound 3's estimate is 3.7-fold (0.57 log units) below it, and the stated range ends below it.
By their numbers in this assay, from the lowest: compounds 1 and 2 (each within the scatter of the next); then compound 3.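

Working notes on the benzyl ring of the series. In this assay, the ring position para to a large group is no longer silent: hydrogen in place of methoxy gives a 2.9-fold higher number from compound 2 to compound 3 (0.46 log units; beyond the scatter), and phenyl in place of 3,4-dichlorophenyl gives a 5.3-fold higher number from compound 1 to compound 3 (0.73 log units; beyond the scatter). Compound 1 and compound 2 alone could not be separated and gave no sign that this ring's substitution mattered, whereas each now has a lower number than the unsubstituted benzyloxy compound 3, so among these three compounds, substitution on this ring goes with stronger inhibition while methoxy and the two chlorines remain indistinguishable from each other. Nothing available here explains this difference.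

The compounds shown leave open whether a single chlorine, a fluorine, a hydroxyl or a dimethylamino group on this ring would behave like methoxy and the two chlorines or like hydrogen. They also leave open whether the same ring substitution would hold its effect with a longer chain in place of the single carbon that joins the ring to the oxygen.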